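Microsomal clearance notes: piperidine to diethylamine on the side chain

The source may report more compounds than this note shows. Statements on the series, on what has been measured and on what is new or still open speak of the compounds shown alone.

Measured so far in an in vitro ADME assay on microsomes from liver (Rattus norvegicus) for pharmacokinetics; a lower number here means slower removal, a higher number faster removal of the compound:
- Compound 1 `Nc1nc(C(F)(F)F)cc2c1[nH]c(=O)n2Cc1ccc(NCCN2CCCC2)nc1`: in this assay compound 1 gives only a limit, < 8.5 mL.min-1.g-1.
- Compound 2 `Nc1nc(C(F)(F)F)cc2c1[nH]c(=O)n2Cc1ccc(NCc2ccccc2)nc1`: in this assay compound 2 gives 16 mL.min-1.g-1.
- Compound 3 `CN(CCN1CCCCC1)c1ccc(Cn2c(=O)[nH]c3c(N)nc(C(F)(F)F)cc32)cn1`: in this assay compound 3 gives 13 mL.min-1.g-1.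

Compound 3 holds the lowest of the two numbers; its nearest neighbour is compound 2, at a 1.2-fold lower number from compound 2 to compound 3 (0.09 log units; within the scatter), a gap within the scatter. Compound 1 sits at a limit of this assay, (the limit of < 8.5 mL.min-1.g-1 in this assay, at which 1 of the 3 values shown sits), so its distance from compound 3 is known only as a floor, an at least 1.5-fold higher number from compound 1 to compound 3 (0.18 log units; that floor lies within the scatter).

Compound 4 `CCN(CC)CCN(C)c1ccc(Cn2c(=O)[nH]c3c(N)nc(C(F)(F)F)cc32)cn1` differs from compound 3 in one place: diethylamino in place of piperidin-1-yl on a saturated chain carbon, two bonds along the chain from a nitrogen on an aromatic ring. The measured steps that touch this side chain are an at least 1.5-fold higher number from compound 1 to compound 3 (0.18 log units; that floor lies within the scatter) and a 1.2-fold lower number from compound 2 to compound 3 (0.09 log units; within the scatter), both small, neither resolved beyond the scatter. The change to compound 4 is smaller still in kind. No step beyond the scatter is expected in this assay. Compound 4 is therefore estimated at 13 mL.min-1.g-1, between 7 mL.min-1.g-1 and 26 mL.min-1.g-1, which is expected to mean no change at the digits printed from compound 3 to compound 4 (within the scatter).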

Compound 4, intrinsic clearance in microsomes: 11 mL.min-1.g-1
Compound 4: the middle estimate sits 1.2-fold (0.07 log units) above what was measured, within the range that was stated.
By their numbers in this assay, from the lowest: compounds 4, 3 and 2 (each within the scatter of the next). At a limit, below all of these: compound 1.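

In this assay, diethylamino in place of piperidin-1-yl gives a 1.2-fold lower number from compound 3 to compound 4 (0.07 log units; within the scatter), so at this place on the chain the closed ring and the open diethylamino group are not told apart. The wider replacement of benzylamino is also unresolved, at a 1.5-fold lower number from compound 2 to compound 4 (0.16 log units; within the scatter), which gives no separation of the basic-looking chain ends from the benzyl end at this level of reading only in the sense that the printed step stays within the scatter. The remaining step, an at least 1.2-fold higher number from compound 1 to compound 4 (0.11 log units; that floor lies within the scatter), is a floor and no more, resting on a limit of the assay: the limit of < 8.5 mL.min-1.g-1 in this assay, at which 1 of the 4 values shown sits.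

As far as these compounds go, whether morpholin-4-yl in place of diethylamino, or a longer chain carrying the same amine, would give a step beyond the scatter stays open. From the compounds shown here alone, the part played by the methyl on the nitrogen bound to the aromatic ring also stays open, since it cannot be read apart from the change at the chain end.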